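A few compounds are considered here, and "the series" means these few. Any claim that something is new, unique, unknown or untested is made for them only; others in the source may bear on it.

Compound 1 `CCCCCCNc1nc(-c2ccccc2)nc2c1nnn2Cc1ccccc1` gives 13200000 nM in an assay on isolated protein for binding affinity to adenosine receptor A1 (Bos taurus); on this read-out higher numbers stand for weaker inhibition and lower numbers for stronger inhibition.
Compound 2 `c1ccc(Cn2nnc3c(NC4CCCC4)nc(-c4ccccc4)nc32)cc1` gives 11000000 nM.
Compound 3 `OC1CCC(Nc2nc(-c3ccccc3)nc3c2nnn3Cc2ccccc2)CC1` gives 2700000 nM.

Compound 3 holds the lowest number of the three, and both gaps lie beyond the scatter: a 4.9-fold lower number from compound 1 to compound 3 (0.69 log units; beyond the scatter) and a 4.1-fold lower number from compound 2 to compound 3 (0.61 log units; beyond the scatter). Compound 4 `CCCCNc1nc(-c2ccccc2)nc2c1nnn2Cc1ccccc1` differs from compound 3 by butyl in place of 4-hydroxycyclohexyl on a nitrogen on an aromatic ring. The step that bears most directly on this change is the reverse of the one already measured, a 4.9-fold lower number from compound 1 to compound 3 (0.69 log units; beyond the scatter), since butyl and hexyl are both plain chains; the step of a 1.2-fold lower number from compound 1 to compound 2 (0.08 log units; within the scatter) adds that hexyl and cyclopentyl gave numbers within the scatter of each other. Compound 4 is therefore expected to move by a 4.1-fold higher number from compound 3 to compound 4 (0.61 log units; beyond the scatter), landing close to compound 1. For compound 4 the estimate is 11000000 nM, with a range of 4000000 nM to 30000000 nM.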

Compound 4, inhibition constant: 11000000 nM
Compound 4: the middle estimate sits on the measured number at the digits printed; the measured number falls inside the stated range.
By their numbers in this assay, from the lowest: compound 3; then compounds 2, 4 and 1 (each within the scatter of the next).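

In this assay, butyl on this nitrogen cannot be told apart from the other plain groups: a 1.2-fold lower number from compound 1 to compound 4 (0.08 log units; within the scatter) and no change at the digits printed from compound 2 to compound 4 (within the scatter) both stay within the scatter. Butyl, hexyl and cyclopentyl therefore form one cluster, whatever their chain length or ring. Compound 3 alone stands apart, and a 4.1-fold higher number from compound 3 to compound 4 (0.61 log units; beyond the scatter) confirms that gap against a third group.

Whether the hydroxyl or the cyclohexyl ring accounts for the gap stays open, as does what plain cyclohexyl, 4-aminocyclohexyl or a hydroxybutyl chain would give. No evidence is available on what lies behind these steps.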